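The source may hold more compounds than are shown below. What is called first, only, known or untested is meant among the compounds shown, and "the series" means these compounds.

Compound 1 `Oc1ccc(O)c(-c2cc(-c3ccc(Cl)cc3)nn2-c2ccccc2)c1` gives 9250 nM in a functional assay on cells (Cancer cell lines, Homo sapiens) for cytotoxicity, read by sulforhodamine B assay, with a stated time of 48 h; a higher number here means a weaker inhibitor of growth, a lower number a stronger inhibitor of growth. Compound 3 `O=C1C=CC(=O)C(c2cc(-c3ccc(Cl)cc3)nn2-c2ccccc2)=C1` is its partner, and compound 3 gives 51500 nM in this assay. The step of a 5.6-fold higher number from compound 1 to compound 3 (0.75 log units; beyond the scatter) comes from a group of 8 heavy atoms (6 carbon, 2 oxygen; one six-membered non-aromatic ring of carbon only) in place of a group of 8 heavy atoms (6 carbon, 2 oxygen; one six-membered aromatic ring of carbon only), on an aromatic carbon. Compound 2 `CC(=O)NS(=O)(=O)c1ccc(-n2nc(-c3ccccc3)cc2-c2cc(O)ccc2O)cc1` gives 91300 nM in this assay; the difference between the cores of compound 1 and compound 2 is not broken down here. Compound 4 `CC(=O)NS(=O)(=O)c1ccc(-n2nc(-c3ccccc3)cc2C2=CC(=O)C=CC2=O)cc1` carries the same kind of change as compound 3, namely (a group of 8 heavy atoms (6 carbon, 2 oxygen; one six-membered non-aromatic ring of carbon only) in place of a group of 8 heavy atoms (6 carbon, 2 oxygen; one six-membered aromatic ring of carbon only), on an aromatic carbon), though the surroundings differ: in compound 1 the place is next to the ring atom that bears a phenyl group and two ring bonds from the ring atom that bears a 4-chlorophenyl group, in compound 2 it is next to the ring atom that bears a large group and two ring bonds from the ring atom that bears a phenyl group. Because a 5.6-fold higher number from compound 1 to compound 3 (0.75 log units; beyond the scatter) was a weakening, a step of a 4.4-fold higher number from compound 2 to compound 4 (0.64 log units; beyond the scatter) is expected for compound 4 in this assay. Compound 4 is estimated at 400000 nM, between 150000 nM and 1000000 nM.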

Compound 4, concentration for 50% growth inhibition: 78500 nM
The estimate for compound 4 lay 5.1-fold (0.71 log units) above the measured number; measured number below the stated range.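

Replacing the 2,5-dihydroxyphenyl group with the non-aromatic ring in this assay gave a 1.2-fold lower number from compound 2 to compound 4 (0.07 log units; within the scatter), so the weakening seen on the core of compound 1 did not recur on the core of compound 2. The two steps differ: the same change on two cores in this assay, a 5.6-fold higher number (0.75 log units; beyond the scatter) from compound 1 to compound 3 and a 1.2-fold lower number (0.07 log units; within the scatter) from compound 2 to compound 4, 6.5-fold (0.81 log units) apart, beyond the scatter of two such steps This shows that the size of the step cannot be carried from one of these cores to the other, but with a single pair on each core and cores that differ in more than one place, it does not show which difference matters.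

The compounds shown leave open whether the 4-chlorophenyl group or the acetyl sulfonamide group governs the step. They also leave open how a carboxylic acid in place of the acetyl sulfonamide would alter it.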